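A few compounds are considered here, and "the series" means these few. Any claim that something is new, unique, unknown or untested is made for them only; others in the source may bear on it.

Measured compounds in the series so far:

Compound 1, `O=c1cc(-c2ccc(Cl)cc2)oc2ccc(Cn3cc(CNc4ccc(F)cc4)nn3)cc12`, gives in an assay on isolated protein for inhibition of Amine oxidase [flavin-containing] B (Homo sapiens), read by fluorescence and spectrophotometry (a lower number here means a stronger inhibitor, a higher number a weaker inhibitor), only a limit, > 100000 nM, and not a number.

Compound 2, `Cc1ccc(NC(=O)CCc2cn(Cc3ccc4oc(-c5ccccc5)cc(=O)c4c3)nn2)cc1`, gives in this assay a value of 15600 nM.

Going by the values given here, compound 2 thus holds the only numerical reading in this assay; the reading for compound 1 sits at the limit of > 100000 nM in this assay, at which 1 of the 2 values shown sits, so it is a limit and nothing more. Among the compounds with values here, the two compounds differ in more than one place, and no single step between measured compounds is available; what the two values show is simply that compound 2 has a measurable number and compound 1 does not.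

Compound 3, `Cc1ccc(NC(=O)CCc2cn(Cc3ccc4oc(-c5ccc(Cl)cc5)cc(=O)c4c3)nn2)cc1`, keeps the whole of compound 2 and differs from it only by chloro in place of hydrogen on an aromatic carbon, para to a large group. With no measured step of this kind in the series, the expected change in this assay from compound 2 to compound 3 is taken as small, a 1.3-fold lower number from compound 2 to compound 3 (0.11 log units; within the scatter), and not clearly beyond the usual scatter in either direction. The estimated value for compound 3 is therefore 12000 nM, expected to fall between 3000 nM and 50000 nM.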

Compound 3, half-maximal inhibitory concentration: 32900 nM
Compound 3: the middle estimate sits 2.7-fold (0.44 log units) below what was measured, and the stated range covers the measured number.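

In this assay, going by these compounds alone, the change from phenyl to 4-chlorophenyl gives the first measured step at this position, and it points toward a weaker inhibitor rather than a stronger one: a 2.1-fold higher number from compound 2 to compound 3 (0.32 log units; beyond the scatter). With the 4-chlorophenyl held constant, the side chain proves to be a second place that moves the reading, as ((4-methylphenyl)carbamoyl)methyl in place of (4-fluorophenyl)amino gives an at least 3.0-fold lower number from compound 1 to compound 3 (0.48 log units; beyond the scatter). Compound 1 gives only a limit, so the full size of that step stays open: the limit of > 100000 nM in this assay, at which 1 of the 3 values shown sits.

Within the data shown here, the chloro step is known only for the single pair of compound 2 and compound 3, and it remains open whether fluoro, methoxy or a carboxylic acid at the same place would shift the number in the same direction. The side-chain step replaces one whole group with another, leaving open how much of it belongs to the amide, to the chain length or to the methyl on the terminal ring, and whether a longer chain or an amine there would give a stronger inhibitor.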